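Rearranging a fused ring on the shared core

A few compounds are considered here, and "the series" means these few. Any claim that something is new, unique, unknown or untested is made for them only; others in the source may bear on it.

Measured compounds:
compound 1, `CN(C)c1ccc(C(=O)Nc2ccc(Oc3ncnc4ccsc34)cc2)cc1`, 50.8%
compound 2, `c1ccc(CNc2ccc(Oc3ncnc4ccsc34)cc2)cc1`, 30.6%
compound 3, `CN(c1ccc(Oc2ncnc3sccc23)cc1)c1nccc(N2CCc3ccccc3C2)n1`, 68.4%

In a functional assay on A549 cells (Homo sapiens) for inhibition, read by MTT assay, with a stated time of 72 h, tested at 20 uM (on this read-out lower numbers stand for less inhibition and higher numbers for more inhibition at the one concentration tested (going by the name of the read-out)), compound 3 gives 68.4%. This is the highest of the three numbers: compound 1 sits closest, and its value is lower by a gap beyond the usual scatter, while compound 2 lies furthest, also beyond the scatter. Compound 4, `CN(c1ccc(Oc2ncnc3ccsc23)cc1)c1nccc(N2CCc3ccccc3C2)n1`, has not been measured. It differs from compound 3 in one place only: the two have the same atoms, joined differently, with the change described as a group of 9 heavy atoms (6 carbon, 2 nitrogen, 1 sulfur; one five-membered aromatic ring with 1 hetero atom, one six-membered aromatic ring with 2 hetero atoms) in place of a group of 9 heavy atoms (6 carbon, 2 nitrogen, 1 sulfur; one five-membered aromatic ring with 1 hetero atom, one six-membered aromatic ring with 2 hetero atoms), on an oxygen on an aromatic ring. Going by the values given here, no step between two measured compounds of this kind has been measured, so there is nothing to calibrate against directly. Since the atoms stay the same and only their arrangement within the fused bicyclic group changes, the expected step from compound 3 to compound 4 is a number 6.4 percentage points lower from compound 3 to compound 4 (within the scatter), a small decrease that may well sit within the scatter. Compound 4 is therefore estimated at 62%, with a range from 45% to 78%.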

Compound 4, a percentage reported as inhibition, at one concentration (the size of the read-out at that concentration, not a potency): 69.9%
Estimate against measurement, compound 4: 7.9 percentage points below; the measured number falls inside the stated range.
By their numbers in this assay, from the lowest: compound 2; then compound 1; then compounds 3 and 4 (each within the scatter of the next).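

In this assay, swapping one arrangement of the fused group for the other, on an oxygen on an aromatic ring, gives a number 1.5 percentage points higher from compound 3 to compound 4 (within the scatter), so these two ways of joining the same atoms cannot be told apart on this read-out. Going by these compounds alone, the earlier compounds could not show this, since none of them formed a pair differing in one place, and this is the first direct reading of what this change does at this position. No supporting measurement is available to explain the result.

Going by these compounds, whether the two arrangements would still read alike with a morpholine or a piperidine in place of the fused amine ring stays open. A reading at a single concentration also leaves open whether they would separate at other concentrations.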